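The source may hold more compounds than are shown below. What is called first, only, known or untested is meant among the compounds shown, and "the series" means these compounds.

Measured in an ADME assay on cells (Hepatocyte, Rattus norvegicus) for pharmacokinetics, read by LC-MS, with a stated time of 90 min, tested at 1 uM; a lower number here means slower removal, a higher number faster removal of the compound:
- compound 1 `CCN(C(=O)OC)c1c(N)nc(-c2nn(Cc3ccccc3F)c3ncccc23)nc1N`: 11.7 mL/min/kg
- compound 2 `CC(C)OC(=O)Nc1c(N)nc(-c2nn(Cc3ccccc3F)c3ncccc23)nc1N`: 15 mL/min/kg
- compound 3 `Nc1nc(-c2nn(Cc3ccccc3F)c3ncccc23)nc(N)c1NC(=O)OCC1CC1`: 23.3 mL/min/kg

Compound 3 stands at 23.3 mL/min/kg, the highest of the three numbers, but it does not separate clearly from the others. There is a 1.6-fold higher number from compound 2 to compound 3 (0.19 log units; within the scatter), and there is a 2.0-fold higher number from compound 1 to compound 3 (0.30 log units; within the scatter). The remaining comparison gives a 1.3-fold higher number from compound 1 to compound 2 (0.11 log units; within the scatter). All three compounds therefore sit within the ordinary noise of this assay.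

Compound 4 `Nc1nc(-c2nn(Cc3ccccc3F)c3ncccc23)nc(N)c1N1CCOC1=O` carries 2-oxo-1,3-oxazolidin-3-yl in place of the (cyclopropylmethoxycarbonyl)amino of compound 3, on an aromatic carbon of a six-membered aromatic ring with 2 nitrogen (2-oxo-1,3-oxazolidin-3-yl in place of (cyclopropylmethoxycarbonyl)amino on an aromatic carbon). Within the data shown here, none of the measured compounds has this five-membered ring, so the evidence is indirect. The nearest guide is compound 1, whose group also lacks the amide hydrogen, and its comparison with compound 3 is a 2.0-fold higher number from compound 1 to compound 3 (0.30 log units; within the scatter) already given. With such small steps, only a modest move towards compound 1 is expected, and no change beyond the scatter can be predicted with confidence.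

The estimate implies an expected 1.7-fold lower number from compound 3 to compound 4 (0.22 log units; within the scatter). For compound 4 the estimated clearance is 14 mL/min/kg, with an expected range of 7 mL/min/kg to 28 mL/min/kg.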

Compound 4, clearance: 6.67 mL/min/kg
Compound 4: the middle estimate sits 2.1-fold (0.32 log units) above what was measured; measured number outside the range, below it.
By their numbers in this assay, from the lowest: compounds 4, 1, 2 and 3 (each within the scatter of the next, the first and the last beyond it).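

In this assay, putting 2-oxo-1,3-oxazolidin-3-yl on this aromatic carbon, ortho to two amino groups, gives steps beyond the scatter against the two compounds that carry an amide hydrogen on the open side chain (a 3.5-fold lower number from compound 3 to compound 4 (0.54 log units; beyond the scatter); a 2.2-fold lower number from compound 2 to compound 4 (0.35 log units; beyond the scatter)). Among these compounds, the earlier compounds showed no step beyond the scatter, so this is the first sign that the group at this position can move the clearance measurably, though the steps are modest. Compound 1 goes against any simple ranking of ring over open chain: its step to the ring stays within the scatter (a 1.8-fold lower number from compound 1 to compound 4 (0.24 log units; within the scatter)), so ethyl(methoxycarbonyl)amino and 2-oxo-1,3-oxazolidin-3-yl cannot be told apart here, and nothing shown explains the result.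

Among the compounds shown here, still open is whether the ring itself matters or only the missing amide hydrogen, as compound 1 is the sole open-chain comparison without that hydrogen and its chain differs from those of compound 2 and compound 3. It is also unknown how the number would respond to 2-oxopyrrolidin-1-yl, which has a ring carbon in place of the ring oxygen, or to a larger six-membered morpholin-3-one ring.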